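Swapping Chloro for Amino on a Shared Core

The source may report more compounds than this note shows. Statements on the series, on what has been measured and on what is new or still open speak of the compounds shown alone.

Compound 1, `ClCc1ccccc1Cn1cnc2c(Cl)nc(Cl)nc21`: 750 nM in a functional assay on HCT-116 cells (Homo sapiens) for cytotoxicity, read by sulforhodamine B assay, with a stated time of 48 h; a lower number here means that less compound is tolerated, a higher number that more compound is tolerated
Compound 3, `ClCc1cccc(Cn2cnc3nc(Cl)nc(Cl)c32)c1`: 4460 nM in this assay
Compound 2, `ClCc1ccc(Cn2cnc3nc(Cl)nc(Cl)c32)cc1`: > 100000 nM in this assay, which is a limit of the assay and not a number

Of the two numbers measured, compound 1 gives the lowest, so the cells tolerate less of it than of any other compound here. Compound 3 gives a higher number, and the gap to compound 1 lies beyond the usual scatter. For compound 2 the assay reports only (the limit of > 100000 nM in this assay, at which 1 of the 3 values shown sits); that value is a limit and nothing more can be read from it.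

Compound 4, `Nc1nc(Cl)c2ncn(Cc3ccccc3CCl)c2n1`, is the next compound to be tested. It differs from compound 1 in a single place: amino in place of chloro on an aromatic carbon. Among the compounds with values here, no pair of measured compounds shows this exchange, so its effect in this assay is open. The expectation is a moderate rise in the number, that is, somewhat more compound tolerated, but a step small enough that it might also fall within the scatter. On that basis compound 4 is estimated at 3000 nM, with a plausible range from 800 nM to 15000 nM, which corresponds to an expected step of a 4.0-fold higher number from compound 1 to compound 4 (0.60 log units; beyond the scatter).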

Compound 4, concentration lethal to 50% of the cells: > 100000 nM
Compound 4 was reported as a limit; the forecaster's own chance of this, stated with the estimate: 15%; at least 33-fold (1.52 log units) between middle value and limit.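

The chloro group on the aromatic carbon between two ring nitrogen atoms turns out to matter a great deal in this assay: amino in its place gives an at least 130-fold higher number from compound 1 to compound 4 (2.12 log units; beyond the scatter). The earlier compounds shown here all carry chloro at this carbon, so they could not show what happens when it is exchanged. The value of compound 4 is a limit and not a number, and the full size of the step stays unknown: the limit of > 100000 nM in this assay, at which 2 of the 4 values shown sit.

Still open, from the compounds shown here alone, is whether the step comes from losing chloro or from gaining amino, a question that a methoxy group, a methylamino group or a plain hydrogen at this carbon could help to separate. Also open, going by these compounds, is how the same exchange would behave at the other chloro group on the shared core.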